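Replacing methylamino with morpholin-4-yl in compound 1

This account rests on a few compounds, and the source may have more. Where it says the series, first, only, none or still open, it means among the compounds named here.

For the measured compounds named here, in a functional assay on MCF7 cells (Homo sapiens) for inhibition, read by sulforhodamine B assay, with a stated time of 72 h (a higher number here means a weaker inhibitor of growth, a lower number a stronger inhibitor of growth), compound 1 `CNC(=O)/C=C/c1ccncc1-c1ccc2ccccc2c1` gives 9340 nM as the only true number so far. Compound 2 `Cn1ncc2cc(-c3cnccc3/C=C/C(=O)O)ccc21` gives > 10000 nM as its reading, which is a limit and not a number. Compound 3 `O=C(/C=C/c1ccncc1-c1ccc2ccccc2c1)N1CCOCC1` differs from compound 1 by morpholin-4-yl in place of methylamino on a carbonyl carbon and so has morpholin-4-yl in place of methylamino on a carbonyl carbon. Going by the values given here, no measured step shows what this swap does, so no change beyond the scatter is expected in this assay here. The expected step of a 1.2-fold higher number from compound 1 to compound 3 (0.07 log units; within the scatter) is therefore small. For compound 3 the estimate is 11000 nM with an expected range from 5000 nM to 25000 nM as its spread.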

Compound 3, concentration for 50% growth inhibition: > 10000 nM
Compound 3: only a limit was reported (the forecaster's own chance of this, stated with the estimate: 55%); the middle value lies beyond the limit too.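

In this assay, compound 3 gives > 10000 nM, which is a limit and not a number. Placing morpholin-4-yl on the carbonyl carbon gives an at least 1.0-fold higher number from compound 1 to compound 3 (0.02 log units; that floor lies within the scatter), so this swap shows no measurable gain in growth inhibition, but the true size of the change remains unknown. This position therefore offers no clear ranking yet: the limit of > 10000 nM in this assay, at which 2 of the 3 values shown sit.

The compounds shown leave open how piperidin-1-yl, which has a carbon in place of the morpholine oxygen, would read at this carbonyl carbon. The same applies to dimethylamino, a small open-chain amine.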